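Thiophen-3-yl for thiophen-2-yl on a shared nucleoside core

The compounds below may be only part of what the source reports. "The series", "measured", "known", "first", "only" and "open" are said of these compounds alone.

The series consists of three measured compounds and one awaiting a result. Compound 1 `O=c1[nH]cnc2c1c(-c1ccsc1)cn2[C@@H]1O[C@H](CO)[C@@H](O)[C@H]1O` gives 14500 nM in a functional assay on CCRF-CEM cells (Homo sapiens), read by MTT assay, with a stated time of 72 h; a lower number here means a stronger inhibitor, a higher number a weaker inhibitor. Compound 3 `CSc1ncnc2c1c(-c1ccoc1)cn2[C@@H]1O[C@H](CO)[C@@H](O)[C@H]1O` gives 14200 nM in this assay, and these two values lie within the scatter of each other. Compound 2 `Cc1nc(N)c2c(-c3cccs3)cn([C@@H]3O[C@H](CO)[C@@H](O)[C@H]3O)c2n1` returns only a limit in this assay, > 20000 nM, so it stands at the weak end of the numbers shown and its value is not a number. the limit of > 20000 nM in this assay, at which 1 of the 3 values shown sits.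

Compound 4 `Cc1nc(N)c2c(-c3ccsc3)cn([C@@H]3O[C@H](CO)[C@@H](O)[C@H]3O)c2n1` differs from compound 2 in one place: thiophen-3-yl in place of thiophen-2-yl on an aromatic carbon. Among the measured compounds shown here, no step between measured compounds is known here, so the size of this change in this assay is open. The two measured numbers and the one limit all sit at weak inhibition, and nothing in them points to a large gain from the change. Compound 4 is therefore expected to remain a weak inhibitor, and the step that the limit leaves unreadable from compound 2 to compound 4 is expected to be no larger than the scatter. The estimate for compound 4 is 25000 nM, with a range from 8000 nM to 80000 nM, and a limit rather than a number is as likely as not.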

Compound 4, half-maximal inhibitory concentration: > 20000 nM
Compound 4: no number, only a limit (the forecaster's own chance of this, stated with the estimate: 60%); the middle value does not contradict the limit.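

Compound 2 and compound 4 each return only a limit in this assay, so no step from one to the other can be read: the limit of > 20000 nM in this assay, at which 2 of the 4 values shown sit.

The compounds shown leave open whether thiophen-3-yl in place of thiophen-2-yl on the shared core changes inhibition at all.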